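Swapping One Halogenated Phenyl Arm for Another

This account rests on a few compounds, and the source may have more. Where it says the series, first, only, none or still open, it means among the compounds named here.

Of the compounds shown here, three have so far been measured in an ADME assay on Huh-7 cells (Homo sapiens) for cytotoxicity; a higher number here means that more compound is tolerated, a lower number that less compound is tolerated. Compound 1 `Cc1ccccc1-c1nn(-c2cccc(Cl)c2)cc1CNCCN1CCN(C)CC1` gives 16000 nM, the highest of the three numbers. Compound 2 `CN1CCN(CCNCc2cn(-c3ccc([N+](=O)[O-])cc3)nc2-c2ccc(OC(F)(F)F)cc2)CC1` gives 4400 nM in this assay, and compound 3 `CCCN1CCC(CNCc2cn(-c3ccc(C(F)(F)F)cc3)nc2-c2ccc(C(F)(F)F)cc2)CC1` gives 1200 nM. The gap from compound 1 to compound 2 lies beyond the scatter, as does the wider gap from compound 1 to compound 3, so compound 1 is the best tolerated of the three. No two of these compounds differ in only one place, and so no single step has been measured.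

Compound 4 `Cc1ccccc1-c1nn(-c2ccc(Br)cc2)cc1CNCCN1CCN(C)CC1` has not yet been measured. It differs from compound 1 in one place: 4-bromophenyl in place of 3-chlorophenyl on an aromatic nitrogen. Nothing measured here isolates the effect of such a change, and the two substituents that exchange are of the same size. The step from compound 1 to compound 4 in this assay is therefore expected to be small, in either direction, and within the scatter. Compound 4 is accordingly estimated at 14000 nM, with a range from 6000 nM to 32000 nM, that estimate meaning a 1.1-fold lower number from compound 1 to compound 4 (0.06 log units; within the scatter).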

Compound 4, half-maximal cytotoxic concentration: 9600 nM
Compound 4: middle estimate off by 1.5-fold (0.16 log units), on the high side, and the stated range covers the measured number.
By their numbers in this assay, from the lowest: compound 3; then compound 2; then compounds 4 and 1 (each within the scatter of the next).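

In this assay, for the compounds shown here, placing 4-bromophenyl where 3-chlorophenyl stood on the aromatic nitrogen gives a 1.7-fold lower number from compound 1 to compound 4 (0.22 log units; within the scatter), the first single-place step. Going by these compounds alone, it shows that, with the rest of compound 1 held constant, this position accepts a change of halogen and of its place on the phenyl ring together without a step beyond the scatter, something the earlier compounds, which differ in several places at once, could not show. No measurement at hand explains this result.

The two parts of this swap remain unseparated, with neither 4-chlorophenyl nor 3-bromophenyl among the compounds shown to tell the halogen from its place on the ring. Also open, going by these compounds, is whether a phenyl group bearing an amine or a carboxylic acid on this nitrogen would stay within the scatter of compound 1.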